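Propyl in place of propargyl on the sulfur of compound 1

This account rests on a few compounds, and the source may have more. Where it says the series, first, only, none or still open, it means among the compounds named here.

Compound 1 `C#CCSc1nc(Nc2cccc(OC)c2)c2ccncc2n1`: 17100 nM
Compound 2 `C#CCSc1nc(Nc2cccc(O)c2)c2ccncc2n1`: > 80000 nM

In a functional assay on PC-3 cells (Homo sapiens) for inhibition, read by MTT assay, with a stated time of 72 h (a lower number here means a stronger inhibitor, a higher number a weaker inhibitor), compound 1 gives 17100 nM, the only number shown. Compound 2 gives > 80000 nM in this assay, which is a limit and not a number. Among the compounds with values here, the one measured step, hydrogen in place of methyl on an oxygen on an aromatic ring, gives an at least 4.6-fold higher number from compound 1 to compound 2 (0.67 log units; beyond the scatter). Compound 3 `CCCSc1nc(Nc2cccc(OC)c2)c2ccncc2n1` differs from compound 1 by ethyl in place of ethynyl on a saturated chain carbon bound to a sulfur. Within the data shown here, no measured step touches this chain, so no change beyond the scatter is expected: a 1.2-fold higher number from compound 1 to compound 3 (0.07 log units; within the scatter). Compound 3 is estimated at 20000 nM, between 7000 nM and 60000 nM.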

Compound 3, half-maximal inhibitory concentration: 15300 nM
Beside the measured number, compound 3's estimate is 1.3-fold (0.12 log units) above it, within the range that was stated.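

In this assay, within the data shown here, the change from propargyl to propyl gives a 1.1-fold lower number from compound 1 to compound 3 (0.05 log units; within the scatter) and is the first measured step on this chain. The triple bond outside aromatic rings can thus be lost with no change beyond the scatter, though this holds only for this one pair. No information given here bears on why the two compounds read alike.

Going by these compounds, what a longer chain, a benzyl group or a terminal amine in place of propyl would do in this assay remains open. So does whether propylsulfanyl could give way to propoxy.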